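This account rests on a few compounds, and the source may have more. Where it says the series, first, only, none or still open, it means among the compounds named here.

Of the compounds shown here, two sharing one core have so far been measured in an assay on HEK293 cells for agonist activity at transient receptor potential cation channel subfamily M member 8 (Homo sapiens), read by fluorescence and calcium flux, with a stated time of 15 min; on this read-out lower numbers stand for an effect already at smaller amounts and higher numbers for an effect only at larger amounts of compound. Compound 1 `Cc1ccc(OCC(=O)N(Cc2cccs2)c2ncco2)cc1` gives 0.3 nM. Among the measured compounds shown here, compound 2 `Cc1ccc(OCC(=O)N(Cc2cccs2)c2ccncc2)cc1` gives 52 nM, the higher of the two numbers, and the single step from compound 1 to compound 2 is a 170-fold higher number from compound 1 to compound 2 (2.24 log units; beyond the scatter). Compound 3 `Cc1ccc(OCC(=O)N(O)Cc2cccs2)cc1` has not yet been measured; it differs from compound 2 by hydroxy in place of pyridin-4-yl on an amide-type nitrogen. For the measured compounds named here, no measured step covers this exchange directly. Going by the values given here, the only guide is the step from compound 1 to compound 2, which swapped one ring for another on the same nitrogen and still moved the read-out a long way. Removing the ring altogether in favour of a hydroxy is a bigger change than that swap, and a further rise in this assay is therefore expected, of about a 12-fold higher number from compound 2 to compound 3 (1.06 log units; beyond the scatter). Compound 3 is estimated at 600 nM, within a range from 60 nM to 6000 nM.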

Compound 3, half-maximal effective concentration: 8000 nM
Compound 3: the middle estimate sits 13-fold (1.12 log units) below what was measured; the measured number lies above the stated range.
By their numbers in this assay, from the lowest: compound 1; then compound 2; then compound 3.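

At this amide-type nitrogen, a hydroxy in place of an aromatic ring carries a heavy penalty in this assay: exchanging the pyridin-4-yl gives a 150-fold higher number from compound 2 to compound 3 (2.19 log units; beyond the scatter), and exchanging the 1,3-oxazol-2-yl gives a 27000-fold higher number from compound 1 to compound 3 (4.43 log units; beyond the scatter). Among these three compounds, the two with a ring on this nitrogen both give much lower numbers than the one without. Even so, the ring is not essential for any effect at all, as compound 3 still gives a number, 8000 nM, though only at far larger amounts.

No evidence here explains these differences. What a methyl or a phenyl on this nitrogen would give remains open, so the compounds shown cannot tell whether the ring itself matters or simply a larger group than hydroxy.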